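This account rests on a few compounds, and the source may have more. Where it says the series, first, only, none or still open, it means among the compounds named here.

Measured so far in a functional assay on BGC-823 cells (Homo sapiens) for antiproliferative activity, read by MTT assay, with a stated time of 72 h; on this read-out higher numbers stand for weaker inhibition and lower numbers for stronger inhibition:
compound 1, `O=C(Nc1cccc(Br)c1)C(Cl)Cl`, 95300 nM
compound 2, `O=C(Nc1cccc([N+](=O)[O-])c1)C(Cl)Cl`, 123000 nM

Compound 2 gives the higher of the two numbers in this assay, but the step of a 1.3-fold higher number from compound 1 to compound 2 (0.11 log units; within the scatter) lies within the scatter, so its number and that of compound 1 are not distinguished. Compound 3, `COc1cccc(NC(=O)C(Cl)Cl)c1`, has not yet been measured. It differs from compound 2 in one place: methoxy in place of nitro on an aromatic carbon. Going by the values given here, the only measured step that bears on this exchange is the one at the same aromatic carbon, a 1.3-fold higher number from compound 1 to compound 2 (0.11 log units; within the scatter), where bromo was replaced by nitro without a change beyond the scatter. On that basis no step beyond the scatter is expected in this assay for the exchange of nitro for methoxy either. Compound 3 is therefore estimated at 100000 nM, with a range from 40000 nM to 250000 nM. The step this estimate implies, a 1.2-fold lower number from compound 2 to compound 3 (0.09 log units; within the scatter), is expected to stay within the scatter.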

Compound 3, half-maximal inhibitory concentration: 179000 nM
For compound 3 the middle estimate is 1.8-fold (0.25 log units) below the measured one; low and high end bracket the measured number.
By their numbers in this assay, from the lowest: compounds 1, 2 and 3 (each within the scatter of the next).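

In this assay, methoxy at this aromatic carbon can be read against two groups: the exchange for nitro gives a 1.5-fold higher number from compound 2 to compound 3 (0.16 log units; within the scatter), and the exchange for bromo gives a 1.9-fold higher number from compound 1 to compound 3 (0.27 log units; within the scatter). A third group, with carbon and oxygen entering where nitro had nitrogen and oxygen, thus still leaves the number undistinguished from those of both earlier compounds, and across these three groups the position shows no step beyond the scatter. Nothing at hand offers an explanation for this result.

Going by these compounds, whether an amine, a carboxylic acid or a longer chain at this carbon would give a step beyond the scatter stays open. So does whether nitro, bromo and methoxy would stay as close together on another carbon of the ring.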